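A few compounds are considered here, and "the series" means these few. Any claim that something is new, unique, unknown or untested is made for them only; others in the source may bear on it.

Three compounds share one core and differ only in a single group on an aromatic ring. Compound 1 `Cc1ccc(S(=O)(=O)NC(=O)Nc2ccccc2C(=O)/C=C/c2cccc(O)c2)cc1` gives 39.3 ug/mL in an ADME assay on the whole organism for cytotoxicity, with Artemia salina as the target, with a stated time of 24 h; on this read-out lower numbers stand for an effect already at smaller amounts and higher numbers for an effect only at larger amounts of compound. Compound 2 `Cc1ccc(S(=O)(=O)NC(=O)Nc2ccccc2C(=O)/C=C/c2ccc(O)cc2)cc1` gives 24.3 ug/mL in this assay, and compound 3 `Cc1ccc(S(=O)(=O)NC(=O)Nc2ccccc2C(=O)/C=C/c2cccc([N+](=O)[O-])c2)cc1` gives 44.5 ug/mL in this assay. Compound 3 thus shows the highest of the three numbers, but the others sit close to it: the step of a 1.1-fold higher number from compound 1 to compound 3 (0.05 log units; within the scatter) and the step of a 1.8-fold higher number from compound 2 to compound 3 (0.26 log units; within the scatter) both stay within the scatter, as does the step of a 1.6-fold lower number from compound 1 to compound 2 (0.21 log units; within the scatter). Compound 4 `Cc1ccc(S(=O)(=O)NC(=O)Nc2ccccc2C(=O)/C=C/c2cccc(Br)c2)cc1` carries bromo in place of nitro on an aromatic carbon. Among the measured compounds shown here, no measured step brings in bromo, so the only guide is that the one exchange made at this same position, a 1.1-fold higher number from compound 1 to compound 3 (0.05 log units; within the scatter), stayed within the scatter, and that none of the three changes went beyond it. For compound 4 in this assay the expectation is therefore no step beyond the scatter, a 1.1-fold lower number from compound 3 to compound 4 (0.05 log units; within the scatter). Compound 4 is estimated at 40 ug/mL, with a range from 20 ug/mL to 80 ug/mL.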

Compound 4, concentration for half-maximal effect: 4.02 ug/mL
Compound 4: the middle estimate sits 10-fold (1.00 log units) above what was measured, and the stated range ends above it.
By their numbers in this assay, from the lowest: compound 4; then compounds 2, 1 and 3 (each within the scatter of the next).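

In this assay, among the compounds shown here, the group at this place on the ring does matter: bromo in place of nitro gives an 11-fold lower number from compound 3 to compound 4 (1.04 log units; beyond the scatter) and is the first step here to go beyond the scatter. The other two compounds point the same way, with a 9.8-fold lower number from compound 1 to compound 4 (0.99 log units; beyond the scatter) for bromo in place of hydroxy and a 6.0-fold lower number from compound 2 to compound 4 (0.78 log units; beyond the scatter) for 3-bromophenyl in place of 4-hydroxyphenyl, so among these four compounds only the bromo compound stands apart, while the hydroxy and nitro compounds stay within the scatter of one another. Nothing available here explains why a single bromine atom separates compound 4 from the others.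

On these data alone, it remains open whether this drop belongs to bromo alone or also appears with chloro, iodo or methyl at this place. An amine or a carboxylic acid here could equally fall with compound 4 or stay with the other three.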